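A few compounds are considered here, and "the series" means these few. Any claim that something is new, unique, unknown or untested is made for them only; others in the source may bear on it.

Compound 1 `N[C@H]1CC[C@H](Nc2c(C(=O)NCc3ccco3)nc(Br)c3cccnc23)CC1`: in a functional assay on HEY cells (Homo sapiens) for cytotoxicity, read by MTT assay, with a stated time of 72 h (a lower number here means a stronger inhibitor, a higher number a weaker inhibitor), compound 1 gives > 10000 nM, which is a limit of the assay, not a number.
Compound 2 `C[C@H](NC(=O)c1nc(Br)c2cccnc2c1N[C@H]1CC[C@H](N)CC1)c1ccc(F)cc1`: in this assay compound 2 gives > 10000 nM, again a limit rather than a number.
Compound 3 `N[C@H]1CC[C@H](Nc2c(C(=O)NCc3ccc(Cl)cc3)nc(Br)c3cccnc23)CC1`: in this assay compound 3 gives 1000 nM.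

Compound 1 therefore stands only at a limit, and it shares that limit with one other compound (the limit of > 10000 nM in this assay, at which 2 of the 3 values shown sit). Against that backdrop the step of an at least 10-fold lower number from compound 1 to compound 3 (1.00 log units; beyond the scatter) shows that exchanging the furan-containing amide substituent for a chlorinated benzyl group does reach a readable number, while a step that the two limits leave unreadable from compound 1 to compound 2 cannot be sized because both ends sit at the limit, and an at least 10-fold lower number from compound 2 to compound 3 (1.00 log units; beyond the scatter) runs in the same direction as the step to compound 3.

The new compound 4 `N[C@H]1CC[C@H](Nc2c(C(=O)Nc3ccccc3)nc(Br)c3cccnc23)CC1` differs from compound 1 by phenyl in place of (furan-2-yl)methyl on an amide-type nitrogen. The measured steps that bear on it are those away from compound 1 and compound 2 toward compound 3, both at least modest lowerings, but neither involves a phenyl set directly on the amide-type nitrogen, so they give only a loose guide. Compound 4 is expected to improve on compound 1 only slightly, the step of an at least 1.6-fold lower number from compound 1 to compound 4 (0.22 log units; that floor lies within the scatter) being the estimate, with a fair chance that the assay again returns only a limit. The estimate for compound 4 in this assay is 6000 nM, within 1500 nM to 25000 nM.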

Compound 4, half-maximal inhibitory concentration: 1000 nM
Compound 4: middle estimate off by 6.0-fold (0.78 log units), on the high side, outside the stated range (below it).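

Phenyl set directly on the amide-type nitrogen gives a readable number, as the 4-chlorobenzyl of compound 3 had done, and the chlorine of that group is therefore not needed for one: there is an at least 10-fold lower number from compound 1 to compound 4 (1.00 log units; beyond the scatter), and an at least 10-fold lower number from compound 2 to compound 4 (1.00 log units; beyond the scatter). The two aromatic groups cannot be told apart in this assay, with no change at the digits printed from compound 3 to compound 4 (within the scatter), so a carbon chain between this nitrogen and the ring is not required either, although the furan-containing compound 1 and the fluorinated compound 2 both carry such a chain and stay unreadable. The two lowerings are floors and not true sizes, because each starts from a limit: the limit of > 10000 nM in this assay, at which 2 of the 4 values shown sit.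

The compounds shown leave open whether the readable numbers depend on a six-membered aromatic ring of carbon only, since compound 1 alone carries a five-membered one and it also differs from compound 4 in its chain carbon. A plain benzyl group, a furan-2-yl set directly on the nitrogen, or a pyridin-3-yl group in place of phenyl would each bear on that question.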